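The source may hold more compounds than are shown below. What is called first, only, known or untested is meant among the compounds shown, and "the series" means these compounds.

In a functional assay on HCT-116 cells (Homo sapiens) for inhibition, read by MTT assay, with a stated time of 48 h (on this read-out lower numbers stand for stronger inhibition and higher numbers for weaker inhibition), two compounds with a shared core have been read so far. Compound 1 (`CCSc1nnc(-c2cc(OC)c(OC)c(OC)c2)n1-c1ccc(N(C)C)cc1`) gives > 60000 nM, which is a limit of the assay and not a number. Compound 2 (`CCOC(=O)CSc1nnc(-c2cc(OC)c(OC)c(OC)c2)n1-c1ccc(N(C)C)cc1`) gives > 60000 nM, again only a limit. Going by the values given here, the sole measured step is a step that the two limits leave unreadable from compound 1 to compound 2, and the record so far amounts to the limit of > 60000 nM in this assay, at which 2 of the 2 values shown sit. Compound 2 therefore stands at the limit, with no measured value of its own.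

Compound 3 (`COc1ccc(NC(=O)CSc2nnc(-c3cc(OC)c(OC)c(OC)c3)n2-c2ccc(N(C)C)cc2)cc1`) carries (4-methoxyphenyl)amino in place of ethoxy on a carbonyl carbon. Among the compounds with values here, the one measured step concerns a different change and has no readable size, so it offers no guide to the size of this one. The expectation rests only on the structural change and on compound 2 at its limit of > 60000 nM. A modest move toward stronger inhibition in this assay is expected, though another limit is quite possible. The expected change is an at least 2.4-fold lower number from compound 2 to compound 3 (0.38 log units; beyond the scatter). Compound 3 is estimated at 25000 nM, with an expected range of 3000 nM to 60000 nM.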

Compound 3, half-maximal inhibitory concentration: > 60000 nM
Compound 3: no number, only a limit; the forecaster's own chance of this, stated with the estimate: 45%; at least 2.4-fold (0.38 log units) between middle value and limit.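

Compound 3, like compound 1 and compound 2, gives only a limit of the assay and not a number, so no step among these three compounds can be read in this assay. The record now amounts to: the limit of > 60000 nM in this assay, at which 3 of the 3 values shown sit.

The compounds shown leave open whether (4-methoxyphenyl)amino in place of ethoxy changes inhibition at all.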